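A Methyl Added on the Side Chain of Compound 2

This account rests on a few compounds, and the source may have more. Where it says the series, first, only, none or still open, it means among the compounds named here.

Compound 1, `CC(C)[C@@H](NS(=O)(=O)Cc1ccccc1)C(=O)N1CCC[C@H]1C(=O)NCc1ccc(C(=N)N)cc1`: 76 nM
Compound 2, `CCC[C@H](NCc1ccc(C(=N)N)cc1)C(=O)[C@@H](CCCNC(=N)N)NS(=O)(=O)Cc1ccccc1`: 15 nM

In an assay on isolated protein for inhibition of transmembrane protease serine 11D (Homo sapiens), read by fluorescence (on this read-out lower numbers stand for stronger inhibition and higher numbers for weaker inhibition), compound 1 gives 76 nM, while compound 2 gives 15 nM. Compound 2 thus has the lower of the two numbers, and its gap to compound 1 lies beyond the scatter. Compound 3, `CC[C@H](C)[C@H](NCc1ccc(C(=N)N)cc1)C(=O)[C@@H](CCCNC(=N)N)NS(=O)(=O)Cc1ccccc1`, awaits measurement. It differs from compound 2 by methyl in place of hydrogen on a saturated chain carbon bound to two saturated chain carbons. Going by the values given here, no measured pair shows this change, so the step can only be judged from the structure itself; it is expected to be small, with no clear direction, and probably within the scatter. Compound 3 is therefore expected to give 15 nM, in the range 5 nM to 45 nM. This estimate means an expected step of no change at the digits printed from compound 2 to compound 3 (within the scatter).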

Compound 3, inhibition constant: 23 nM
Beside the measured number, compound 3's estimate is 1.5-fold (0.19 log units) below it; measured number inside the range.
By their numbers in this assay, from the lowest: compounds 2 and 3 (each within the scatter of the next); then compound 1.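

Going by these compounds alone, measured in this assay the change from propyl to sec-butyl, methyl in place of hydrogen on a saturated chain carbon bound to two saturated chain carbons, gives a 1.5-fold higher number from compound 2 to compound 3 (0.19 log units; within the scatter) and is the first reading at this position. It shows that this position takes the added methyl with no shift that can be told from the scatter. Nothing measured here gives a reason for this result.

The compounds shown leave open how a longer chain, cyclohexyl, an amine or a carboxylic acid would read at this position.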